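Swapping isopropyl for propargyl on the ring nitrogen

The compounds below may be only part of what the source reports. "The series", "measured", "known", "first", "only" and "open" are said of these compounds alone.

Two compounds have been measured:
- compound 1, `CCCN1N=C2/C(=C/c3ccccc3C)CSCC2C1c1ccccc1C`, 31%
- compound 2, `CC(C)N1N=C2/C(=C/c3cccc(C(F)(F)F)c3)CS(=O)(=O)CC2C1c1cccc(C(F)(F)F)c1`, 31%

Both were tested in a functional assay on the whole organism with Mus musculus as the target, at a dose of 150 mg/kg by the intraperitoneal route; a higher number here means more inhibition at the dose given (going by the name of the read-out), a lower number less inhibition. Compound 1 gives 31%. Compound 2 gives 31%, which is level with compound 1 at the digits shown; the two values lie within the usual scatter of each other, so no order between them can be read off.

Compound 3, `C#CCN1N=C2/C(=C/c3cccc(C(F)(F)F)c3)CS(=O)(=O)CC2C1c1cccc(C(F)(F)F)c1`, has not yet been measured. It differs from compound 2 in one place: propargyl in place of isopropyl on an amine nitrogen in a ring. The change sits on an amine nitrogen in a ring, and both groups are small chains of the same heavy-atom count, the new one carrying a triple bond outside aromatic rings.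

Among the compounds with values here, no step between two measured compounds is known here, so there is nothing to scale this change against. The two measured values suggest that a small change at the edge of the shared core need not move the read-out. For compound 3 the step from compound 2 is expected to be no change at the digits printed from compound 2 to compound 3 (within the scatter), that is, no change beyond the scatter in either direction. Compound 3 is therefore estimated at 31%, with a range from 10% to 55%.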

Compound 3, a percentage reported as inhibition, in the whole organism at one dose (the size of the read-out at that dose, not a potency): 31%
Estimate against measurement, compound 3: no gap at the digits printed; low and high end bracket the measured number.
By their numbers in this assay, from the lowest: compounds 1, 2 and 3 (each within the scatter of the next).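

In this assay, within the data shown here, propargyl in place of isopropyl on an amine nitrogen in a ring gives no change at the digits printed from compound 2 to compound 3 (within the scatter), the first step here between two compounds that differ in one place only. It shows that, at this position and this single dose, the read-out does not separate these two small chains, although the entering group brings a triple bond outside aromatic rings and the leaving group has none. No measurement here offers an explanation for this flat result.

Both groups have the same heavy-atom count, so this one step says nothing about how the read-out responds to a larger change at this ring nitrogen, such as a longer chain like hexyl, a benzyl group, or a chain ending in an amine or a carboxylic acid. It also leaves open whether compound 2 and compound 3 would still read alike at other doses, since a reading at one dose gives the size of the effect at that dose and not a potency.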